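This account rests on a few compounds, and the source may have more. Where it says the series, first, only, none or still open, it means among the compounds named here.

Compound 1 `NC1=NC2(CCSCC2)N(OCCCOc2ccc(Cl)c(Cl)c2)C(N)=N1` was examined in an assay on isolated protein for inhibition of Dihydrofolate reductase (Homo sapiens), read by spectrophotometry, using NADPH, with stated times of 5 s and 6 min, tested at 50 uM; a higher number here means a stronger effect of the compound at the concentration tested, a lower number a weaker effect. In this assay compound 1 gives 89.8%. Among the compounds with a number in this assay, compound 1 stands highest of two, but its nearest neighbour lies within the usual scatter: compound 2 `NC1=NC2(CCOCC2)N(OCCCOc2ccccc2Cl)C(N)=N1` gives 88.2% in this assay, so no order between the two can be read from these figures. A third member of the series, compound 3 `NC1=NC2(CCOCC2)N(OCCCOc2ccc(F)cc2)C(N)=N1`, has no number in this assay; for compound 3 the entry reads "not determined" (no result reported).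

Compound 4 `NC1=NC2(CCSCC2)N(OCCCOc2cccc(Cl)c2Cl)C(N)=N1` differs from compound 1 only in how the same atoms are joined: 2,3-dichlorophenyl in place of 3,4-dichlorophenyl on an oxygen on a saturated carbon. Within the data shown here, no step between two measured compounds of this kind is available, so the expectation rests on the values of compound 1 and compound 2 alone, which both sit high in this assay. The step of a number 4.8 percentage points lower from compound 1 to compound 4 (within the scatter) is expected to be small and not beyond the scatter, with at most a slight drift downward. Compound 4 is therefore estimated to give 85% in this assay, within a range from 70% to 95%.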

Compound 4, a percentage reported as inhibition, at one concentration (the size of the read-out at that concentration, not a potency): 89.8%
Estimate against measurement, compound 4: 4.8 percentage points below, within the range that was stated.
By their numbers in this assay, from the lowest: compounds 2, 1 and 4 (each within the scatter of the next).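

In this assay, among these compounds, there is no change at the digits printed from compound 1 to compound 4 (within the scatter) when 2,3-dichlorophenyl stands in place of 3,4-dichlorophenyl on an oxygen on a saturated carbon, and this is the first step that can be read at this place. Among the compounds shown here, compounds 1 and 2 differ in more than one place, so only this pair shows that, at the single concentration tested, the read-out does not separate these two arrangements of the same atoms on the shared core. Nothing at hand bears on why the two arrangements read alike.

Going by these compounds, whether the two compounds would also read alike at lower concentrations stays open, since a single-concentration percentage is not a potency. Also open, on these data alone, is how the read-out would respond at this place to a pyridine ring or to a carboxylic acid on the phenyl ring.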